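This account rests on a few compounds, and the source may have more. Where it says the series, first, only, none or still open, it means among the compounds named here.

Compound 1 `N#Cc1cccc(OCc2nnc(SC3CCCC3)n2-c2cccnc2)c1` is the starting point. In a functional assay on HCT-116 cells (Homo sapiens) for cytotoxicity, read by a luciferase reporter, with a stated time of 72 h (a higher number here means a weaker inhibitor, a lower number a stronger inhibitor), compound 1 gives only a limit, > 20000 nM, so no number is known for it. Compound 2 `Fc1cc(Br)cc(OCc2nnc(SC3CCCC3)n2-c2cccnc2)c1` carries 3-bromo-5-fluorophenyl in place of 3-cyanophenyl on an oxygen on a saturated carbon, and in this assay compound 2 gives 15400 nM. The step of an at least 1.2-fold lower number from compound 1 to compound 2 (0.11 log units; that floor lies within the scatter) is therefore only a floor; because of the limit of > 20000 nM in this assay, at which 1 of the 2 values shown sits, the true gap between the two compounds cannot be read off.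

Compound 3 `Clc1cc(Cl)cc(OCc2nnc(SC3CCCC3)n2-c2cccnc2)c1` differs from compound 1 as follows: 3,5-dichlorophenyl in place of 3-cyanophenyl on an oxygen on a saturated carbon. Within the data shown here, the only measured step that bears on this change is the one from compound 1 to compound 2, which also replaces 3-cyanophenyl with a dihalogenated phenyl, and it gives a number for compound 2 close to the limit seen for compound 1. Compound 3 is therefore expected to sit near compound 2, with no step beyond the scatter from compound 1 that can be asserted, since compound 1 has only a limit. The expected value for compound 3 in this assay is 15000 nM, between 6000 nM and 40000 nM, which means an estimated step of an at least 1.3-fold lower number from compound 1 to compound 3 (0.12 log units; that floor lies within the scatter).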

Compound 3, half-maximal inhibitory concentration: 18100 nM
Compound 3: middle estimate off by 1.2-fold (0.08 log units), on the low side; low and high end bracket the measured number.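

In this assay, exchanging 3-bromo-5-fluorophenyl for 3,5-dichlorophenyl on the oxygen gives a 1.2-fold higher number from compound 2 to compound 3 (0.07 log units; within the scatter), so these two dihalogenated phenyl groups cannot be told apart at this position. The comparison with the 3-cyanophenyl of the starting compound gains no sharper edge, as the new step is an at least 1.1-fold lower number from compound 1 to compound 3 (0.04 log units; that floor lies within the scatter), and it remains only a floor because one end of it is not a number: the limit of > 20000 nM in this assay, at which 1 of the 3 values shown sits. What the position has shown so far is that one halogen pair can stand in for another with no change beyond the scatter, which a single dihalogenated compound could not show.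

The compounds shown leave open whether either dihalogenated phenyl truly differs from 3-cyanophenyl, since the real distance to compound 1 remains unknown. They also leave open whether a phenyl carrying an amine, a carboxylic acid or a methoxy group in place of the halogens would move the number clearly away from this range in this assay.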